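The source may report more compounds than this note shows. Statements on the series, on what has been measured and on what is new or still open speak of the compounds shown alone.

Measured so far:
compound 1 `O=C(COc1ccc(C(=O)/C=C/c2ccccc2Cl)cc1)N[C@H]1CCOC1=O` — 27100 nM in a functional assay on MGC-803 cells (Homo sapiens) for antiproliferative activity, read by MTT assay, with a stated time of 72 h; on this read-out lower numbers stand for stronger inhibition and higher numbers for weaker inhibition
compound 2 `O=C1OCC[C@@H]1NC(=S)SCCOc1cccc2ccccc12` — > 64000 nM in this assay

In this assay, among the compounds with values here, compound 1 gives 27100 nM, the only number recorded for the series. For compound 2 the result in this assay is > 64000 nM, which is a limit of the assay and not a number; it marks (the limit of > 64000 nM in this assay, at which 1 of the 2 values shown sits). Within the data shown here, compound 1 and compound 2 are not linked by any single-point change, so no measured step exists and the usual scatter is the only scale to hand.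

Compound 3 `O=C(COc1ccc(C(=O)/C=C/c2ccc(Br)cc2)cc1)N[C@H]1CCOC1=O` is still to be measured. It differs from compound 1 by 4-bromophenyl in place of 2-chlorophenyl on a double-bonded chain carbon bound to a double-bonded chain carbon. Among the measured compounds shown here, with no measured step to lean on, the expected step of a 1.1-fold lower number from compound 1 to compound 3 (0.04 log units; within the scatter) is none beyond the scatter, in neither direction. Compound 3 is therefore estimated at 25000 nM in this assay, with a range from 10000 nM to 64000 nM.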

Compound 3, half-maximal inhibitory concentration: 51000 nM
The estimate for compound 3 lay 2.0-fold (0.31 log units) below the measured number; measured number inside the range.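

In this assay, within the data shown here, the first measured step on the core of compound 1 is a 1.9-fold higher number from compound 1 to compound 3 (0.27 log units; within the scatter) for 4-bromophenyl in place of 2-chlorophenyl. Among these compounds, this gives the first reading at this place, on a double-bonded chain carbon bound to a double-bonded chain carbon: a change in both the halogen and the substitution named on the phenyl ring leaves the two compounds within the scatter of each other. No measured property available here bears on this step.

The halogen and its place on the phenyl ring change together, so 4-chlorophenyl or 2-bromophenyl would be needed to read each change alone. Whether this place can give a step beyond the scatter also stays open, as only halogen-bearing phenyl groups are shown and no phenyl carrying an amine or a carboxylic acid appears among them.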